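This account rests on a few compounds, and the source may have more. Where it says the series, first, only, none or still open, it means among the compounds named here.

Measured so far:
- compound 1 `CC(C)N(C(=O)n1cnc(S[C@@H]2C[C@H]3CC[C@@H]2C3)n1)C(C)C`: 22 mL.min-1.g-1
- compound 2 `O=C(N1CCCC1)n1cnc(S(=O)(=O)[C@@H]2C[C@H]3CC[C@@H]2C3)n1`: > 30 mL.min-1.g-1 (a limit of the assay, not a number)

For the measured compounds named here, in an ADME assay (liver, Mus musculus) for metabolic stability, using microsomes (a higher number here means faster removal of the compound, a lower number slower removal), compound 1 gives 22 mL.min-1.g-1, the only true number so far. Compound 3 `O=C(N1CCCC1)n1cnc(S[C@@H]2C[C@H]3CC[C@@H]2C3)n1` is not yet measured. It keeps the core of compound 1, with pyrrolidin-1-yl in place of diisopropylamino on a carbonyl carbon. Going by the values given here, no measured pair shows this change, so the expectation in this assay is no step beyond the scatter, in either direction. The expected value for compound 3 is 20 mL.min-1.g-1, within an estimated range of 10 mL.min-1.g-1 to 30 mL.min-1.g-1.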

Compound 3, intrinsic clearance in microsomes: > 30 mL.min-1.g-1
Compound 3: a limit, no number; the forecaster's own chance of this, stated with the estimate: 25%; middle value at least 1.5-fold (0.17 log units) from the limit.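

Pyrrolidin-1-yl in place of diisopropylamino on a carbonyl carbon gives an at least 1.3-fold higher number from compound 1 to compound 3 (0.13 log units; that floor lies within the scatter) in this assay as the only readable step in the series. Compound 3 stands at a limit, so this step is a floor and does not establish a change beyond the scatter. Its full size cannot be read because the readings stop at the limit: the limit of > 30 mL.min-1.g-1 in this assay, at which 2 of the 3 values shown sit.

On these data alone, it remains open whether morpholin-4-yl or dimethylamino on a carbonyl carbon would give a true number in this assay rather than a limit.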